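A Second Fluoro on the Sulfonyl Aryl of Compound 2

The compounds below may be only part of what the source reports. "The series", "measured", "known", "first", "only" and "open" are said of these compounds alone.

Compound 1 `CC1(c2ccc(-c3cccc(/C(N)=N\O)c3)cc2)CC(S(=O)(=O)c2ccc(F)cc2)=C(c2ccc(/C(N)=N\O)cc2)O1` gives 11000 nM in an ADME assay on J774.A1 cells (Mus musculus) for cytotoxicity, read by MTT assay, with a stated time of 72 h; a higher number here means that more compound is tolerated, a lower number that less compound is tolerated. Compound 2 `CC1(Cc2ccccc2)CC(S(=O)(=O)c2ccccc2F)=C(c2ccc(/C(N)=N\O)cc2)O1` gives 29100 nM. Compound 3 `CC1(c2ccc(Br)cc2)CC(S(=O)(=O)c2ccc(F)cc2)=C(c2ccc(/C(N)=N\O)cc2)O1` gives 10500 nM.

Among these three numbers compound 2 stands highest in this assay: compound 1 is the nearest to it and compound 3 the furthest, and both gaps lie beyond the scatter. Going by the values given here, the only measured step between neighbours, a 1.0-fold lower number from compound 1 to compound 3 (0.02 log units; within the scatter), exchanges a large group for a single bromine atom and stays within the scatter.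

Compound 4 `CC1(Cc2ccccc2)CC(S(=O)(=O)c2c(F)cccc2F)=C(c2ccc(/C(N)=N\O)cc2)O1` differs from compound 2 by fluoro in place of hydrogen on an aromatic carbon. Among the compounds with values here, no measured step bears on this change: the step from compound 1 to compound 3 concerns a different group at a different place, and none of the measured compounds carries a second fluoro on the sulfonyl aryl. The account therefore expects no step beyond the scatter, a 1.2-fold lower number from compound 2 to compound 4 (0.07 log units; within the scatter), and reads it as an estimate carried over from compound 2. Compound 4 is estimated at 25000 nM, expected to fall between 12000 nM and 50000 nM.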

Compound 4, half-maximal cytotoxic concentration: 27000 nM
Compound 4: middle estimate off by 1.1-fold (0.03 log units), on the low side; the measured number falls inside the stated range.
By their numbers in this assay, from the lowest: compounds 3 and 1 (each within the scatter of the next); then compounds 4 and 2 (each within the scatter of the next).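

In this assay, going by these compounds alone, the change from 2-fluorophenyl to 2,6-difluorophenyl gives a 1.1-fold lower number from compound 2 to compound 4 (0.03 log units; within the scatter), and this is the first measured step that touches the sulfonyl aryl. The earlier compounds shown here showed only a change elsewhere in the molecule, whereas this result shows that a fluoro in place of hydrogen at this place, ortho to a large group, does not move the number beyond the scatter. Nothing measured here gives a reason for this result.

As far as these compounds go, it remains open whether a larger group at this place, such as a methoxy group, an amine or a carboxylic acid, would also leave the number within the scatter. The compounds shown also leave open whether a second fluoro on the sulfonyl aryl would behave in the same way in compound 1 or compound 3.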